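Phenoxy for trifluoromethyl in a series at its limit

A few compounds are considered here, and "the series" means these few. Any claim that something is new, unique, unknown or untested is made for them only; others in the source may bear on it.

Two members of the series have been measured so far: compound 1 `CC1(COc2ccc(Cl)cc2)Cn2cc([N+](=O)[O-])nc2O1` and compound 2 `CC1(COc2ccc(C(F)(F)F)cc2)Cn2cc([N+](=O)[O-])nc2O1`. In an ADME assay on MRC5 cells (Homo sapiens) for cytotoxicity, read by fluorescence, with a stated time of 72 h (a higher number here means a weaker inhibitor, a lower number a stronger inhibitor), compound 1 gives > 64000 nM, which is a limit of the assay and not a number. In this assay compound 2 gives > 64000 nM, which is also a limit. Compound 2 therefore has no exact position, and the only reference point is the limit of > 64000 nM in this assay, at which 2 of the 2 values shown sit.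

Compound 3 `CC1(COc2ccc(Oc3ccccc3)cc2)Cn2cc([N+](=O)[O-])nc2O1` carries phenoxy in place of trifluoromethyl on an aromatic carbon, para to a large group: phenoxy in place of trifluoromethyl on an aromatic carbon. Within the data shown here, the one measured change at this place is a step that the two limits leave unreadable from compound 1 to compound 2. Among the measured compounds shown here, that step offers no size to carry over, and phenoxy has no measured counterpart. No clear shift is therefore expected in this assay, and a reported limit remains the likeliest result. If a number does appear, it is expected on the stronger side. The expected step is a number no higher from compound 2 to compound 3 (the limit leaves the size open), with nothing expected beyond the scatter. For compound 3 the estimated value is 64000 nM, with an expected range of 32000 nM to 128000 nM.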

Compound 3, half-maximal inhibitory concentration: > 64000 nM
Compound 3: no number, only a limit (the forecaster's own chance of this, stated with the estimate: 75%); the middle value sits exactly at the limit.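

The steps among compound 1, compound 2 and compound 3 cannot be read, because all three values are limits of the assay and not numbers: the limit of > 64000 nM in this assay, at which 3 of the 3 values shown sit. In this assay the compounds shown leave open how far each lies from that limit, and whether chloro, trifluoromethyl and phenoxy differ at all at this place.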